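This account rests on a few compounds, and the source may have more. Where it says the series, first, only, none or still open, it means among the compounds named here.

Of the compounds shown here, three have so far been measured in an assay on CHO cells for displacement of a labelled ligand from prostaglandin D2 receptor 2 (Homo sapiens), read by scintillation counting; on this read-out higher numbers stand for weaker inhibition and lower numbers for stronger inhibition. Compound 1, `CN(C)C(=O)c1cccc(C#Cc2cc(Cl)ccc2OCC(=O)O)c1`, gives 52 nM in this assay. Compound 2, `CCCS(=O)(=O)c1cccc(C#Cc2cc(F)ccc2OCC(=O)O)c1`, gives 65 nM, and compound 3, `CC(C)(C)N1C(=O)c2ccc(C#Cc3cc(Cl)ccc3OCC(=O)O)cc2S1(=O)=O`, gives 14 nM. Among these three numbers compound 1 holds the second highest. Its nearest neighbour is compound 2, whose number lies within the usual scatter of repeated measurements, so no order between compound 1 and compound 2 can be read from these two values. Compound 3 is the furthest away, with a lower number that lies beyond the scatter.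

Compound 4, `CN(C)S(=O)(=O)c1cccc(C#Cc2cc(Cl)ccc2OCC(=O)O)c1`, has not yet been measured. It differs from compound 1 in a single place: dimethylsulfamoyl in place of dimethylcarbamoyl on an aromatic carbon. Within the data shown here, no measured pair in this set shows exactly this exchange, so the size of the step cannot be taken from a measured one. Among the measured compounds shown here, the only hint comes from compound 2, which gives 65 nM, a number close to that of compound 1 despite a different group at the same part of the core. On that basis the step expected here is a 1.0-fold lower number from compound 1 to compound 4 (0.02 log units; within the scatter), meaning none beyond the scatter in either direction. For compound 4 the expected value in this assay is therefore 50 nM, with a range from 20 nM to 130 nM.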

Compound 4, inhibition constant: 14 nM
Compound 4: the middle estimate sits 3.6-fold (0.55 log units) above what was measured, outside the stated range (below it).
By their numbers in this assay, from the lowest: compounds 3 and 4 (each within the scatter of the next); then compounds 1 and 2 (each within the scatter of the next).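

In this assay, placing dimethylsulfamoyl in place of dimethylcarbamoyl on this aromatic carbon, meta to a large group, gives a 3.7-fold lower number from compound 1 to compound 4 (0.57 log units; beyond the scatter). Among these compounds, this is the first measured exchange in the set that changes a single place, and it shows that the number responds to the choice between these two groups even though both carry the same pair of methyl groups on nitrogen and the rest of the molecule stays the same. The data offer no measurement that explains what about the exchange produces this step.

On these data alone, this finding rests on a single pair of compounds, so it remains open whether the same exchange would give a similar step on a core carrying fluorine rather than chlorine. It is also unclear how the number would respond to other groups at this place, such as an unsubstituted sulfamoyl, a methylsulfonyl or a pyrrolidinylsulfonyl group, which could help show which part of dimethylsulfamoyl matters for the result.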